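The source may report more compounds than this note shows. Statements on the series, on what has been measured and on what is new or still open speak of the compounds shown alone.

Compound 1 `C=C1CN/C(=N/c2ccccc2)S1`: > 100000 nM
Compound 2 `COc1ccc(/C=C2/CN(C)/C(=N/c3ccc(C)cc3)S2)cc1`: 7600 nM
Compound 3 `COc1ccc(/C=C2\S/C(=N\c3ccc(Cl)cc3)N(C)C2=O)cc1`: 39300 nM

The values come from a functional assay on MCF7 cells (Homo sapiens) for antiproliferative activity, read by MTT assay, with a stated time of 72 h; a lower number here means a stronger inhibitor, a higher number a weaker inhibitor. The entry for compound 1, > 100000 nM, is a limit of the assay and not a number. Among the two actual numbers, compound 2 has the lower, at 7600 nM, making it the stronger inhibitor of the pair; compound 3 reads 39300 nM.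

Compound 4 `COc1ccc(/C=C2/CN(C)/C(=N/c3ccc(Cl)cc3)S2)cc1` differs from compound 2 in one place: chloro in place of methyl on an aromatic carbon, para to a large group (chloro in place of methyl on an aromatic carbon). Within the data shown here, no measured pair of compounds shows this change on its own. In this assay, no shift beyond the usual scatter is expected, and neither direction is favoured. The expected change is a 1.1-fold lower number from compound 2 to compound 4 (0.04 log units; within the scatter). For compound 4, the estimated value is 7000 nM, with an expected range of 2500 nM to 20000 nM.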

Compound 4, half-maximal inhibitory concentration: 7600 nM
Compound 4: middle estimate off by 1.1-fold (0.04 log units), on the low side; measured number inside the range.
By their numbers in this assay, from the lowest: compounds 2 and 4 (each within the scatter of the next); then compound 3. At a limit, above all of these: compound 1.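

In this assay, among these compounds, the earlier compounds held no pair that isolated this position, and now one does: chloro replaces methyl on an aromatic carbon, para to a large group, giving no change at the digits printed from compound 2 to compound 4 (within the scatter). At this position, then, 4-methylphenyl and 4-chlorophenyl cannot be told apart by this read-out. Nothing measured here says why these two groups read alike.

Still open, going by these compounds, is how a quite different group at the same position, such as an amine or a carboxylic acid, would read. One swap also cannot show whether this position tolerates change in general.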